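Larger Aromatic Group in Place of Isobutyl

The source may hold more compounds than are shown below. What is called first, only, known or untested is meant among the compounds shown, and "the series" means these compounds.

Compound 1 `CC(C)Cc1ccc2c(NCCCNCc3ccco3)ccnc2c1`: 16000 nM
Compound 2 `COc1ccc(F)cc1CNCCCNc1ccnc2cc(CC(C)C)ccc12`: 2900 nM
Compound 3 `COc1ccc(F)cc1CNCCCNc1ccnc2cc(-c3ccccc3)ccc12`: 2960 nM

In an ADME assay on HepG2 cells (Homo sapiens) for cytotoxicity, read by luminescence, CellTiter-Glo and ATP content, with a stated time of 72 h (a higher number here means that more compound is needed for the effect, a lower number that less compound is needed), compound 1 gives 16000 nM, the highest of the three numbers, while compound 2 gives 2900 nM and compound 3 gives 2960 nM, both beyond the scatter below compound 1. The step of a 5.5-fold lower number from compound 1 to compound 2 (0.74 log units; beyond the scatter) alters only the group on the saturated chain carbon and does not bear on compound 4. Compound 4 `CC(C)(C)c1ccc(-c2ccc3c(NCCCNCc4ccco4)ccnc3c2)cc1` differs from compound 1 thus: 4-(tert-butyl)phenyl in place of isobutyl on an aromatic carbon. The comparable measured step, a 1.0-fold higher number from compound 2 to compound 3 (0.01 log units; within the scatter), lies within the scatter. Compound 4 is therefore expected to stay close to compound 1, with no step beyond the scatter: no change at the digits printed from compound 1 to compound 4 (within the scatter). Compound 4 is estimated at 16000 nM, between 7000 nM and 36000 nM.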

Compound 4, half-maximal effective concentration: 3150 nM
For compound 4 the middle estimate is 5.1-fold (0.71 log units) above the measured one, and the stated range ends above it.
By their numbers in this assay, from the lowest: compounds 2, 3 and 4 (each within the scatter of the next); then compound 1.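

On the aromatic carbon that carries isobutyl in compound 1, this change is not neutral in this assay: 4-(tert-butyl)phenyl in place of isobutyl gives a 5.1-fold lower number from compound 1 to compound 4 (0.71 log units; beyond the scatter). The earlier change at this position, with a different group on the saturated chain, gave a 1.0-fold higher number from compound 2 to compound 3 (0.01 log units; within the scatter), so a larger aromatic group here does not always leave the number unchanged. No evidence is available that explains this shift. From the compounds shown here alone, it remains open how plain phenyl would read with the furan-2-yl side chain. Also open, going by these compounds, is how a phenyl bearing a carboxylic acid or an amine would read at this position.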